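The compounds below may be only part of what the source reports. "The series", "measured", "known", "first", "only" and "open" are said of these compounds alone.

Compound 1 `CCN(CC)CCCn1c(N)c(-c2nc3ccccc3n2C)c2nc(C#N)c(C#N)nc21` and compound 2 `CN(C)CCCCn1c(N)c(-c2nc3ccccc3n2C)c2nc(C#N)c(C#N)nc21` share one core, while compound 3 `CCN(CC)CCn1c(N)c(-c2nc3cc(Cl)ccc3[nH]2)c2nc(C#N)c(C#N)nc21` and compound 4 `CN(C)CCCn1c(N)c(-c2nc3cc(Cl)ccc3[nH]2)c2nc(C#N)c(C#N)nc21` share another. In a functional assay on HL60/MX2 cells (Homo sapiens) for antiproliferative activity, read by MTT assay, with a stated time of 48 h (on this read-out higher numbers stand for weaker inhibition and lower numbers for stronger inhibition), compound 1 gives 4470 nM, and compound 2 gives 2580 nM. The change between these two, ((dimethylamino)methyl in place of diethylamino on a saturated chain carbon, three bonds along the chain from an aromatic nitrogen), makes a step of a 1.7-fold lower number from compound 1 to compound 2 (0.24 log units; within the scatter). Compound 3 gives 9290 nM in this assay, the highest of the three numbers measured; the difference between its core and the core of compound 1 is not broken down here. Compound 4 differs from compound 3 by (dimethylamino)methyl in place of diethylamino on a saturated chain carbon, two bonds along the chain from an aromatic nitrogen. This is the same kind of change as that from compound 1 to compound 2, not the same: in the earlier pair the change sits on a saturated chain carbon, three bonds along the chain from an aromatic nitrogen, whereas here it sits on a saturated chain carbon, two bonds along the chain from an aromatic nitrogen. Going by the values given here, the only measured step of this kind, a 1.7-fold lower number from compound 1 to compound 2 (0.24 log units; within the scatter), lies within the scatter of repeated measurements, so nothing here points to a large move for compound 4. Compound 4 is therefore expected to give about 5500 nM in this assay, with the estimate reaching from 2500 nM to 12000 nM. The step this estimate means, a 1.7-fold lower number from compound 3 to compound 4 (0.23 log units; within the scatter), is expected to be small because the earlier step of a 1.7-fold lower number from compound 1 to compound 2 (0.24 log units; within the scatter) was itself small.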

Compound 4, half-maximal inhibitory concentration: 5310 nM
Compound 4: middle estimate off by 1.0-fold (0.02 log units), on the high side; measured number inside the range.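

In this assay, the new step, a 1.7-fold lower number from compound 3 to compound 4 (0.24 log units; within the scatter), can be set directly beside the step seen on the core of compound 1, and the two agree: the same change on two cores in this assay, a 1.7-fold lower number (0.24 log units; within the scatter) from compound 1 to compound 2 and a 1.7-fold lower number (0.24 log units; within the scatter) from compound 3 to compound 4, 1.0-fold (0.00 log units) apart, within the scatter of two such steps Within these two pairs, then, the exchange of diethylamino for (dimethylamino)methyl carries from one core to the other with no detectable difference in the size of the step, even though it sits two bonds along the chain from an aromatic nitrogen in one pair and three bonds along in the other. This does not show that the change itself alters antiproliferative activity, since each step lies within the scatter of repeated measurements, so the agreement is one between two small steps, and two pairs cannot establish a rule for the whole series.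

The compounds shown leave open how the numbers would run with a longer chain carrying the dimethylamino group, or with a secondary amine or a carboxylic acid in its place. They also leave open whether the same change would give a step of similar size on any core other than these two.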